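A few compounds are considered here, and "the series" means these few. Any claim that something is new, unique, unknown or untested is made for them only; others in the source may bear on it.

Compound 1 `Cc1cc(NC(=O)Nc2cc(F)cc(F)c2)c2ccccc2n1`: in an ADME assay on HepG2 cells (Homo sapiens) for cytotoxicity, with a stated time of 72 h (on this read-out higher numbers stand for an effect only at larger amounts of compound and lower numbers for an effect already at smaller amounts), compound 1 gives > 25000 nM, which is a limit of the assay and not a number.
Compound 2 `Cc1cc(NC(=O)Nc2cc(Cl)cc(Cl)c2)c2ccccc2n1`: in this assay compound 2 gives > 25000 nM, likewise a limit of the assay.

Compound 2 therefore stands at a limit only, without a number of its own. Compound 3 `Cc1cc(NC(=O)Nc2cccc(Cl)c2)c2ccccc2n1` differs from compound 2 by hydrogen in place of chloro on an aromatic carbon. Going by the values given here, no step between measured compounds exists here. Compound 2 sits at the limit of > 25000 nM in this assay, at which 2 of the 2 values shown sit, so for compound 3 a step of no size beyond the scatter is expected, a number no higher from compound 2 to compound 3 (the limit leaves the size open). Compound 3 is estimated at 25000 nM, between 12000 nM and 50000 nM, most likely again reported as a limit.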

Compound 3, half-maximal effective concentration: 19000 nM
Estimate against measurement, compound 3: 1.3-fold (0.12 log units) above, within the range that was stated.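

With hydrogen in place of chloro on an aromatic carbon, the series shows an at least 1.3-fold lower number from compound 2 to compound 3 (0.11 log units; that floor lies within the scatter). In this assay, going by these compounds alone, compound 3 gives 19000 nM, the only value so far that is a number and not a limit. The true size of this change cannot be read, as compound 2 is held at a limit of the assay: the limit of > 25000 nM in this assay, at which 2 of the 3 values shown sit.

The compounds shown leave open whether the remaining chloro can also give way to hydrogen without a change in the number. They also leave open what an amine or a carboxylic acid would do on this aromatic carbon.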